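The source may report more compounds than this note shows. Statements on the series, on what has been measured and on what is new or still open speak of the compounds shown alone.

Measured compounds:
compound 1, `CC(O)(C(=O)Nc1ccc(S(=O)(=O)c2ccccc2)c(O)c1)C(F)(F)F`, 430 nM
compound 2, `CC(O)(C(=O)Nc1ccc(S(=O)(=O)c2ccccc2Cl)cc1)C(F)(F)F`, 2300 nM

Both were run in a functional assay (Cavia porcellus) with sulfonylurea receptors; K-ATP channels (Homo sapiens) as the target; a lower number here means a stronger inhibitor, a higher number a weaker inhibitor. Compound 2 holds the highest number of the two; its nearest neighbour is compound 1, whose number is lower by a margin that lies beyond the scatter, so compound 2 reads as the weaker inhibitor of the pair. Among the compounds with values here, compound 1 and compound 2 differ in more than one place, so no single step between them can be drawn, and no step between measured compounds is available as a guide.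

The next compound, compound 3, `CC(O)(C(=O)Nc1ccc(S(=O)(=O)c2cnccn2)cc1)C(F)(F)F`, is not yet measured in this assay. Its difference from compound 2 is pyrazin-2-yl in place of 2-chlorophenyl on a sulfonyl sulfur. Nothing in the measured pair isolates this exchange on the sulfonyl sulfur, so the expectation for compound 3 rests on compound 2 alone, with wide uncertainty. The step from compound 2 to compound 3 is expected to be a 1.3-fold higher number from compound 2 to compound 3 (0.12 log units; within the scatter), a small shift towards a higher number that may well sit within the scatter. Compound 3 is therefore estimated at 3000 nM, with a range from 800 nM to 12000 nM.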

Compound 3, half-maximal inhibitory concentration: 12000 nM
Beside the measured number, compound 3's estimate is 4.0-fold (0.60 log units) below it, and the stated range covers the measured number.
By their numbers in this assay, from the lowest: compound 1; then compound 2; then compound 3.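

In this assay, within the data shown here, the exchange of 2-chlorophenyl for pyrazin-2-yl on a sulfonyl sulfur gives a 5.2-fold higher number from compound 2 to compound 3 (0.72 log units; beyond the scatter), and this is the only step so far that changes one place. It shows that the group on the sulfonyl sulfur affects the read-out with the rest of the molecule held constant, and that here the ring with hetero atoms goes with weaker inhibition than the chlorinated carbon-only ring. No measurement shown gives a reason for this step.

Among these compounds, the single step changes the ring atoms and removes the chlorine together, so the share of each in the shift stays open. On these data alone, how a pyridyl, a methoxyphenyl or an unsubstituted phenyl group on the sulfonyl sulfur would read against compound 2 and compound 3 on the same core also stays open, and with it whether the trend holds beyond this one pair.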